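The compounds below may be only part of what the source reports. "The series", "measured", "known", "first", "only" and "open" are said of these compounds alone.

In a functional assay on MDA-MB-231 cells (Homo sapiens) for cytotoxicity, read by MTT assay, with a stated time of 24 h (a lower number here means a stronger inhibitor, a higher number a weaker inhibitor), compound 1 `c1ccc(-c2nc3cccnc3n2C2CCCC2)cc1` gives 3000 nM. Compound 2 `c1ccc(Oc2ccc(-c3nc4cccnc4n3C3CCCC3)cc2)cc1` gives > 10000 nM, which is a limit and not a number. Compound 3 `O=C(O)c1ccc(-c2nc3cccnc3n2C2CCCC2)cc1` gives 600 nM, the lowest number of the three. Compound 4 `COC(=O)c1ccc(-c2nc3cccnc3n2C2CCCC2)cc1` differs from compound 3 in one place: methyl in place of hydrogen on an oxygen next to a carbonyl group, with methyl in place of hydrogen on an oxygen next to a carbonyl group, so carboxy becomes methoxycarbonyl. The closest guide is a 5.0-fold lower number from compound 1 to compound 3 (0.70 log units; beyond the scatter), where carboxy replaced hydrogen. A second guide, an at least 3.3-fold higher number from compound 1 to compound 2 (0.52 log units; beyond the scatter), shows that not every group added there lowers the number. Part of the gain from carboxy is therefore expected to be lost. The expected change is a 2.5-fold higher number from compound 3 to compound 4 (0.40 log units; beyond the scatter), a modest move to a higher number. The estimate for compound 4 is 1500 nM, with an expected range of 500 nM to 5000 nM.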

Compound 4, half-maximal inhibitory concentration: 350 nM
Compound 4: middle estimate off by 4.3-fold (0.63 log units), on the high side, and the stated range ends above it.
By their numbers in this assay, from the lowest: compounds 4 and 3 (each within the scatter of the next); then compound 1. At a limit, above all of these: compound 2.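

In this assay, the hydrogen on the oxygen of the carboxy group is not required at this position, since replacing it with methyl gives a 1.7-fold lower number from compound 3 to compound 4 (0.23 log units; within the scatter). Methoxycarbonyl keeps the gain seen with carboxy over the unsubstituted compound, with an 8.6-fold lower number from compound 1 to compound 4 (0.93 log units; beyond the scatter), and it also gives an at least 28-fold lower number from compound 2 to compound 4 (1.45 log units; beyond the scatter). Compound 2 sits at a limit, not a number, so that last step is only a bound: the limit of > 10000 nM in this assay, at which 1 of the 4 values shown sits.

From the compounds shown here alone, whether a larger ester such as ethoxycarbonyl, or an amide, would hold the number at this position stays open. So does whether an amine there would lose the gain.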